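The source may hold more compounds than are shown below. What is called first, only, known or untested is meant among the compounds shown, and "the series" means these compounds.

Three analogues carry numbers in a functional assay on the whole organism for inhibition, with Mus musculus as the target, at a dose of 10 mg/kg by the oral route; a higher number here means more inhibition at the dose given (going by the name of the read-out), a lower number less inhibition. Compound 1 `CSc1ccc2c(c1)c(O)c(C(=O)N(C)c1ccccc1)c(=O)n2C` gives 67%. Compound 2 `COc1ccc2c(c1)c(O)c(C(=S)N(C)c1ccccc1)c(=O)n2C` gives 31%. Compound 3 `COc1cccc(N(C)/C(S)=C2/C(=O)c3cc(Cl)ccc3N(C)C2=O)c1` gives 30%, the lowest of the three: compound 2 sits within the scatter of it, while compound 1 lies beyond the scatter above it. Within the data shown here, no two of these measured compounds differ in one place only, so no single step is known.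

Compound 4 `CN1C(=O)/C(=C(/S)N(C)c2cccc(Cl)c2)C(=O)c2cc(Cl)ccc21` is the next entry and differs from compound 3 by one change: chloro in place of methoxy on an aromatic carbon. With no step of this kind in the series, the expectation is a step from compound 3 to compound 4 of a number 5 percentage points higher from compound 3 to compound 4 (within the scatter) in this assay, not beyond the scatter in either direction. Compound 4 is estimated at 35%, in the range 15% to 55%.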

Compound 4, a percentage reported as inhibition, in the whole organism at one dose (the size of the read-out at that dose, not a potency): 63%
The estimate for compound 4 lay 28 percentage points below the measured number; the whole stated range lies below it.
By their numbers in this assay, from the lowest: compounds 3 and 2 (each within the scatter of the next); then compounds 4 and 1 (each within the scatter of the next).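

In this assay, among these compounds, the change from 3-methoxyphenyl to 3-chlorophenyl gives a number 33 percentage points higher from compound 3 to compound 4 (beyond the scatter) and is the first single-place comparison. Among the compounds shown here, the earlier compounds differed in more than one place, so only this pair shows that the group on this aromatic carbon alone can shift the read-out by a large step. No measurement at hand bears on why.

Going by these compounds, whether an amine, a carboxylic acid or a longer alkoxy chain on this carbon would sit nearer compound 3 or compound 4 stays open. On these data alone, the step also rests on one pair, so its size on the other cores is unknown.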